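A smaller heteroaryl amide in place of the phenylpyrazole

The source may hold more compounds than are shown below. What is called first, only, known or untested is meant among the compounds shown, and "the series" means these compounds.

Of the compounds shown here, three sharing one core have been measured in an assay on isolated protein for binding affinity to Discoidin domain-containing receptor 2 (Homo sapiens), read by thermal shift assay, tested at 10 uM; on this read-out higher numbers stand for stronger stabilisation of the target against heat and lower numbers for weaker stabilisation of the target. Compound 1 `CS(=O)(=O)N1CCCC(NC(=O)[C@H](CCC2CCCCC2)NC(=O)c2ccc(CNC(=O)c3cc(-c4ccccc4)n[nH]3)cc2)C1` gives 2 degrees C. Compound 2 `CC(NC(=O)c1cc(-c2ccccc2)n[nH]1)c1ccc(C(=O)N[C@@H](CCC2CCCCC2)C(=O)NC2CCCN(S(C)(=O)=O)C2)cc1` gives 1.7 degrees C in this assay, the smallest of the three numbers, while its gaps to compound 3 and to compound 1 are both within the scatter. Compound 3 `CC(NC(=O)c1cc(-c2ccccc2)n[nH]1)c1ccc(C(=O)N[C@@H](CCC2CCCCC2)C(=O)N[C@@H]2CCCN(S(C)(=O)=O)C2)cc1` gives 1.9 degrees C in this assay. The measured steps are small: a number 0.30 degrees C lower from compound 1 to compound 2 (within the scatter) and a number 0.20 degrees C higher from compound 2 to compound 3 (within the scatter), the second pair differing only in the fact that one of compounds 2 and 3 is drawn with a defined configuration and the other without, at the place where they differ.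

Compound 4 `CC(NC(=O)c1cnn(C)c1N)c1ccc(C(=O)N[C@@H](CCC2CCCCC2)C(=O)NC2CCCN(S(C)(=O)=O)C2)cc1` differs from compound 2 on a carbonyl carbon: a group of 7 heavy atoms (4 carbon, 3 nitrogen; one five-membered aromatic ring with 2 hetero atoms) in place of a group of 11 heavy atoms (9 carbon, 2 nitrogen; one five-membered aromatic ring with 2 hetero atoms, one six-membered aromatic ring of carbon only), on a carbonyl carbon. Neither measured step touches this part of the molecule, so none bears directly on the change; both lay within the scatter across this small set. The change here is larger than either measured step, removing the six-membered aromatic ring of carbon only, and some loss of stabilisation is expected in this assay. Compound 4 is therefore expected to give 0.9 degrees C in this assay, between -0.4 degrees C and 2.2 degrees C. The expected step is a number 0.80 degrees C lower from compound 2 to compound 4 (within the scatter).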

Compound 4, shift of the target's melting temperature: 6.7 degrees C
Estimate against measurement, compound 4: 5.8 degrees C below; the measured number lies above the stated range.
By their numbers in this assay, from the lowest: compounds 2, 3 and 1 (each within the scatter of the next); then compound 4.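

The exchange on the carbonyl carbon gives a number 5.0 degrees C higher from compound 2 to compound 4 (beyond the scatter) in this assay, showing that this position can move the read-out well beyond the scatter, which neither earlier step touching other parts of the molecule had done. Removing the six-membered aromatic ring of carbon only therefore brings no loss of stabilisation in this pair, although the whole group changes at once and the contributions of its parts cannot be separated. Nothing available bears on the reason for this step.

From the compounds shown here alone, whether the amine or the methyl on the entering ring carries the step remains open, as a plain 1H-pyrazole or a pyridine on the same carbonyl carbon would help to tell. Also open, going by these compounds, is whether the step holds with the configuration drawn as in compound 3.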